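Phenoxy exchange on the shared core: compound 1 to compound 4

The source may hold more compounds than are shown below. What is called first, only, known or untested is meant among the compounds shown, and "the series" means these compounds.

Compound 1 `Nc1cc(N)c2nc(-c3ccccc3)c(Oc3ccc(Cl)c(Cl)c3)nc2c1` — in a functional assay on SW-620 cells (Homo sapiens) for inhibition, read by sulforhodamine B assay, with a stated time of 48 h (on this read-out higher numbers stand for weaker inhibition of growth and lower numbers for stronger inhibition of growth), compound 1 gives 30200 nM.
Compound 2 `COc1ccc(CNc2nc3cc(N)cc(N)c3nc2-c2ccccc2)cc1OC` — in this assay compound 2 reaches only the limit < 100000 nM, a limit and not a number.
Compound 3 `CCOC(=O)[C@H](CCC(=O)O)NC(=O)c1ccc(Sc2nc3cc(N)cc(N)c3nc2-c2ccccc2)cc1` — in this assay compound 3 reaches only the limit < 100000 nM, again a limit and not a number.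

Within the data shown here, compound 1 therefore stands as the only number in the set; the other two readings sit at the limit of < 100000 nM in this assay, at which 2 of the 3 values shown sit. Among the measured compounds shown here, no pair of measured compounds differs in a single place, so no measured step sets a scale for what an exchange at the phenoxy group does on this core.

Compound 4 `Nc1cc(N)c2nc(-c3ccccc3)c(Oc3ccc(F)cc3)nc2c1` differs from compound 1 by 4-fluorophenyl in place of 3,4-dichlorophenyl on an oxygen on an aromatic ring. With nothing measured on either side of this exchange, the expectation rests on compound 1 alone: a step in this assay of modest size, toward weaker inhibition of growth, and one that may well stay within the scatter of repeated measurements. Compound 4 is thus estimated at 50000 nM, with a range from 12000 nM to 150000 nM; the expected step is a 1.7-fold higher number from compound 1 to compound 4 (0.22 log units; within the scatter). Because compound 1 already sits close to the limit of < 100000 nM in this assay, at which 2 of the 3 values shown sit, a reading of compound 4 that is itself only a limit remains a real possibility.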

Compound 4, concentration for total growth inhibition: 50100 nM
Compound 4: middle estimate off by 1.0-fold (0.00 log units), on the low side; the range from low to high includes it.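

In this assay, among these compounds, 4-fluorophenyl in place of 3,4-dichlorophenyl on an oxygen on an aromatic ring gives the first step that can be read at this position on the shared core: a 1.7-fold higher number from compound 1 to compound 4 (0.22 log units; within the scatter). The two halogen patterns therefore cannot be ordered on this read-out, and this change at the phenoxy group, with both chlorine atoms leaving and one fluorine entering, produces no step beyond the scatter. Compound 4 also gives a number and not a limit, so the phenoxy pair can be read directly, while compound 2 and compound 3 remain at a limit, which is not a number: the limit of < 100000 nM in this assay, at which 2 of the 4 values shown sit.

Among the compounds shown here, what stays open is whether any group on this oxygen moves the reading beyond the scatter, as the one step available joins two halogen-bearing phenyl rings and sets no scale for a larger change. An unsubstituted phenyl, or a phenyl ring carrying an amine or a carboxylic acid, would test this position further, and would show whether the reading can leave the narrow band held by compound 1 and compound 4.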